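This account rests on a few compounds, and the source may have more. Where it says the series, first, only, none or still open, it means among the compounds named here.

Compound 1 `CCCc1cnc(N2CCC(C3Cc4cc(C5=CCN(S(=O)(=O)CCC)CC5)ccc4O3)CC2)nc1` is the reference point of this set. In a functional assay on HEK293 cells for agonist activity at Glucose-dependent insulinotropic receptor (Homo sapiens), read by cAMP accumulation, with a stated time of 60 min (a higher number here means that more compound is needed for the effect, a lower number that less compound is needed), compound 1 gives 82 nM. Compound 2 `CCCc1cnc(N2CCC(C3Cc4c(ccc(C5=CCN(S(=O)(=O)CCC)CC5)c4F)O3)CC2)nc1` carries a single change relative to compound 1, (fluoro in place of hydrogen on an aromatic carbon), and in this assay compound 2 gives 5 nM; the step is a 16-fold lower number from compound 1 to compound 2 (1.21 log units; beyond the scatter). Compound 3 `CCCc1cnc(N2CCC(C3Cc4cc(C5=CCN(S(=O)(=O)CCCO)CC5)cc(F)c4O3)CC2)nc1` is built on a different core, and the difference between the two cores is not broken down here. In this assay compound 3 gives 122 nM, a number close to that of compound 1 and well apart from that of compound 2.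

Compound 4 `CCCc1cnc(N2CCC(C3Cc4c(F)c(C5=CCN(S(=O)(=O)CCCO)CC5)cc(F)c4O3)CC2)nc1` has not yet been measured. It differs from compound 3 by fluoro in place of hydrogen on an aromatic carbon. For the measured compounds named here, this is the same kind of change as the one from compound 1 to compound 2, but the surroundings are not identical: in compound 4 the entering fluoro also sits para to a fluoro group (1 heavy atom), a feature absent around the place of change in compound 2. Going by the values given here, the expectation for the step is a 6.1-fold lower number from compound 3 to compound 4 (0.79 log units; beyond the scatter), a gain that is estimated to be real but smaller than the one seen from compound 1 to compound 2, because that earlier step of a 16-fold lower number from compound 1 to compound 2 (1.21 log units; beyond the scatter) was measured on a core that had no fluoro already in place, and it is only one observation. On that basis compound 4 is expected to give about 20 nM in this assay, with a range from 5 nM to 80 nM considered plausible.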

Compound 4, half-maximal effective concentration: 16 nM
Beside the measured number, compound 4's estimate is 1.3-fold (0.10 log units) above it; low and high end bracket the measured number.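

In this assay the fluoro in place of hydrogen on an aromatic carbon gives a 7.6-fold lower number from compound 3 to compound 4 (0.88 log units; beyond the scatter) and so again lowers the number, this time on a core where the entering fluoro sits para to a fluoro group. The gain therefore carries over from one core to the other, and its size cannot be told apart between the two cores: the same change on two cores in this assay, a 16-fold lower number (1.21 log units; beyond the scatter) from compound 1 to compound 2 and a 7.6-fold lower number (0.88 log units; beyond the scatter) from compound 3 to compound 4, 2.2-fold (0.33 log units) apart, within the scatter of two such steps. For the compounds shown here, this rests on only two pairs, however, and their cores differ in more than one place, including the hydroxyl at the end of the sulfonyl chain in compound 3 and compound 4, so the data neither show that the gain would hold on further cores nor separate the influence of the fluoro already in place from that of the chain.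

The compounds shown leave open whether a chloro or a methyl group on that aromatic carbon would lower the number as the fluoro does. They also leave open how the same step would read with an amine or a carboxylic acid in place of the hydroxyl at the end of the sulfonyl chain.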